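Shifting the anilide pattern on the shared core

This account rests on a few compounds, and the source may have more. Where it says the series, first, only, none or still open, it means among the compounds named here.

Compound 1 `Cc1cc(C)cc(NC(=O)CN2CCC(c3cccc[n+]3[O-])CC2)c1`: 52 nM
Compound 2 `Cc1cc(NC(=O)CN2CCC(c3cccc[n+]3[O-])CC2)ccc1F`: 18 nM

In a functional assay on HEK293 cells for agonist activity at D(4) dopamine receptor (Homo sapiens), read by FLIPR (on this read-out higher numbers stand for an effect only at larger amounts of compound and lower numbers for an effect already at smaller amounts), compound 2 gives 18 nM, the lowest number of the two measured compounds. Going by the values given here, its nearest neighbour, compound 1, gives 52 nM, and the single measured step, a 2.9-fold lower number from compound 1 to compound 2 (0.46 log units; beyond the scatter), is a modest one that lies beyond the scatter. That step exchanged one substituted phenyl for another on the amide-type nitrogen.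

Compound 3 `O=C(CN1CCC(c2cccc[n+]2[O-])CC1)Nc1ccc(F)cc1F` has not yet been measured. It differs from compound 2 by 2,4-difluorophenyl in place of 4-fluoro-3-methylphenyl on an amide-type nitrogen. Among the compounds with values here, no measured step covers this exact exchange. Within the data shown here, the one step available, a 2.9-fold lower number from compound 1 to compound 2 (0.46 log units; beyond the scatter), shows that changing the substitution pattern of the phenyl on the amide-type nitrogen moves the number by a modest amount, so a step of similar size, in either direction, is the reasonable expectation for compound 3, with a slight lean toward a higher number since compound 2 is already the lowest point seen. Compound 3 is therefore expected to give about 30 nM, within a range of 8 nM to 120 nM, which corresponds to an expected step of a 1.7-fold higher number from compound 2 to compound 3 (0.22 log units; within the scatter).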

Compound 3, half-maximal effective concentration: 103 nM
Estimate against measurement, compound 3: 3.4-fold (0.54 log units) below; the measured number falls inside the stated range.
By their numbers in this assay, from the lowest: compound 2; then compounds 1 and 3 (each within the scatter of the next).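

The exchange at this position shows that the low number of compound 2 in this assay does not carry over to every fluorinated phenyl on the amide-type nitrogen: 2,4-difluorophenyl keeps a fluorine in the 4-position of the name yet gives a 5.7-fold higher number from compound 2 to compound 3 (0.76 log units; beyond the scatter). The second new step, a 2.0-fold higher number from compound 1 to compound 3 (0.30 log units; within the scatter), puts 3,5-dimethylphenyl and 2,4-difluorophenyl level despite their different substituents, so of the three groups only 4-fluoro-3-methylphenyl stands apart, with its steps to both others beyond the scatter. Nothing available explains why this one combination of methyl and fluorine gives the lowest number, and no measurement of any property of these groups bears on the result.

The compounds shown leave open how much of the number of compound 2 belongs to its methyl and how much to its fluorine, since both change together in each step. They also leave open how an unsubstituted phenyl, or a phenyl carrying a chlorine or a methoxy group, would sit among these three on the shared core.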